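The source may report more compounds than this note shows. Statements on the series, on what has been measured and on what is new or still open speak of the compounds shown alone.

Two compounds carrying thiophen-2-yl on the shared core come first, compound 1 (`CSc1ncnc2c1c(-c1cccs1)cn2[C@@H]1O[C@H](CO)[C@@H](O)[C@H]1O`) and compound 2 (`Cc1ncnc2c1c(-c1cccs1)cn2[C@@H]1O[C@H](CO)[C@@H](O)[C@H]1O`). In a functional assay on HCT-116 cells (Homo sapiens), read by MTT assay, with a stated time of 72 h (on this read-out lower numbers stand for stronger inhibition and higher numbers for weaker inhibition), compound 1 gives > 20000 nM, which is a limit of the assay and not a number. In this assay, compound 2 gives > 20000 nM, again only a limit, so compound 2 has no readable potency.

Compound 3 (`Cc1ncnc2c1c(I)cn2[C@@H]1O[C@H](CO)[C@@H](O)[C@H]1O`) carries iodo in place of thiophen-2-yl on an aromatic carbon of the five-membered aromatic ring: iodo in place of thiophen-2-yl on an aromatic carbon. For the measured compounds named here, the one measured step, a step that the two limits leave unreadable from compound 1 to compound 2, concerns methyl in place of methylsulfanyl and has no readable size, so it gives no measure for this change. The evidence amounts to the limit of > 20000 nM in this assay, at which 2 of the 2 values shown sit, and both compounds behind it carry thiophen-2-yl. Going by the values given here, compound 3 is the first without that group. Any readable result for it would have to lie on the side of stronger inhibition, so a move in that direction is expected, though with little support for its size. The expected step is an at least 6.6-fold lower number from compound 2 to compound 3 (0.82 log units; beyond the scatter). In this assay, the estimated value for compound 3 is 3000 nM, with an expected range from 300 nM to 20000 nM.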

Compound 3, half-maximal inhibitory concentration: 4720 nM
Estimate against measurement, compound 3: 1.6-fold (0.20 log units) below, and the stated range covers the measured number.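

In this assay, for the compounds shown here, replacing thiophen-2-yl with iodo on this aromatic carbon of the five-membered aromatic ring gives an at least 4.2-fold lower number from compound 2 to compound 3 (0.62 log units; beyond the scatter), the first readable change and the first sign that the read-out responds to the group at this position. The step between the methylsulfanyl and methyl compounds cannot be read, so the earlier pair gave no such sign, and the size of the new step is only a lower bound, as it starts from a limit of the assay. Thiophen-2-yl is carried by both compounds that remain at the limit and is absent from the only compound with a readable number: the limit of > 20000 nM in this assay, at which 2 of the 3 values shown sit.

Going by these compounds, what remains open is whether the gain belongs to iodo itself or follows from the loss of thiophen-2-yl, and how a bromo, a phenyl or an amine on the same carbon would read in this assay. Also open, on these data alone, is whether methylsulfanyl and methyl, the two groups compared in the earlier pair, would differ measurably on a core that carries iodo.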